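The compounds below may be only part of what the source reports. "The series", "measured", "known", "first", "only" and "open" are said of these compounds alone.

Working notes on the series, with an ADME assay for permeability, using PAMPA (a lower number here means that the compound crosses the layer more slowly, a higher number that the compound crosses the layer faster), as the read-out of interest. Compound 1 `O=C(Nc1ccc([N+](=O)[O-])cc1Cl)c1cc(F)ccc1O` has no number to start from: its entry stands as "not determined" (no result reported). The same holds for compound 2 `O=C(Nc1ccc([N+](=O)[O-])cc1Cl)c1ccc(Cl)cc1O`, whose entry is "not determined" (no result reported). Compound 3 `COc1ccc(C(=O)Nc2ccc([N+](=O)[O-])cc2Cl)c(O)c1` gives < 3 10^-6 cm/s, and this is a limit of the assay, not a number. Within the data shown here, the series therefore offers no single measured permeability, and no pair of compounds yields a measured step.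

The next compound is compound 4 `COc1ccc(O)c(C(=O)Nc2ccc([N+](=O)[O-])cc2Cl)c1`. The change is methoxy in place of fluoro on an aromatic carbon, para to a hydroxy group. With compound 1 unmeasured, the size of this change in this assay cannot be read from the data, so no step beyond the usual scatter is expected and no direction is assigned. Among the measured compounds shown here, the only guide is compound 3, which also bears a methoxy group and is recorded at < 3 10^-6 cm/s, a limit. A reported limit is therefore a likely outcome for the new compound as well, and a number close to that limit is the expected alternative. For compound 4 the estimated permeability is 2.5 10^-6 cm/s, with an expected range of 1 10^-6 cm/s to 8 10^-6 cm/s.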

Compound 4, apparent permeability: 67.1 10^-6 cm/s
For compound 4 the middle estimate is 27-fold (1.43 log units) below the measured one; the measured number lies above the stated range.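

In this assay compound 4 gives 67.1 10^-6 cm/s against no single number for compound 1, the compound that differs from it in one place, and no step can be read between the two. The compounds shown leave open what methoxy in place of fluoro, para to a hydroxy group, does to this read-out on the shared core.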